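Moving the attachment point of a saturated ring group

The compounds below may be only part of what the source reports. "The series", "measured", "known", "first", "only" and "open" are said of these compounds alone.

In a functional assay on the whole organism for agonist activity, with Rattus norvegicus as the target (a higher number here means that more compound is needed for the effect, a lower number that less compound is needed), compound 1, `c1ccc2c(c1)CCC2CCCN1CCN(c2cccc3c2OCCO3)CC1`, gives 10 mg/kg. Compound 3, `c1ccc2c(c1)CC2CN1CCN(c2cccc3c2OCCO3)CC1`, gives 10 mg/kg in this assay, so compound 1 and compound 3 stand level within the usual scatter of the measurement. Compound 2, `c1ccc2c(c1)CC2CN1CCN(c2cccc3c2OCCCO3)CC1`, reaches only a limit of the assay in this assay, > 10 mg/kg, and not a number. That value sits at the limit of > 10 mg/kg in this assay, at which 1 of the 3 values shown sits.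

Compound 4, `c1ccc2c(c1)CC(CCCN1CCN(c3cccc4c3OCCO4)CC1)C2`, has not yet been measured. It is built from the same atoms as compound 1, joined differently: 2,3-dihydro-1H-inden-2-yl in place of 2,3-dihydro-1H-inden-1-yl on a saturated chain carbon, three bonds along the chain from an amine nitrogen in a ring. Among the compounds with values here, no pair of measured compounds shows this kind of change, so there is no measured step to lean on, and the two measured numbers that exist are themselves level with each other. Compound 4 is therefore expected to show a step of no change at the digits printed from compound 1 to compound 4 (within the scatter) that is none beyond the scatter. Compound 4 is estimated at 10 mg/kg in this assay, within a range from 3 mg/kg to 30 mg/kg.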

Compound 4, minimum effective dose: 40 mg/kg
For compound 4 the middle estimate is 4.0-fold (0.60 log units) below the measured one; measured number outside the range, above it.
By their numbers in this assay, from the lowest: compounds 1 and 3 (each within the scatter of the next); then compound 4.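

In this assay, the attachment point alone makes a measurable difference: with the same atoms, 2,3-dihydro-1H-inden-2-yl in place of 2,3-dihydro-1H-inden-1-yl gives a 4.0-fold higher number from compound 1 to compound 4 (0.60 log units; beyond the scatter), so more compound is needed for the effect. Within the data shown here, the earlier compounds offered no pair differing in one place, so this is the first measured step at this position, and it shows that the result depends on how the ring group is joined to the saturated chain. Nothing measured here says why the step arises.

This single step comes from one pair, so it cannot show whether the same move would have a similar effect on another chain or core. The compounds shown also leave open how a longer chain, or an amine in place of the 2,3-dihydro-1H-inden-2-yl group, would fare at this place.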